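Phenyl for Cyclohexyl on a Quinoline-Free Description of the Core

The source may hold more compounds than are shown below. What is called first, only, known or untested is meant among the compounds shown, and "the series" means these compounds.

Of the compounds shown here, three have been measured so far. Compound 1 `COc1cc2c(NCc3ccc(-c4ccc(C(=O)NO)cc4)cc3)cc(-c3ccc(C)o3)nc2cc1OCCCN1CCCC1` gives 127 nM in an assay on isolated protein for inhibition of protein deacetylase HDAC6 (Homo sapiens), read by fluorescence, with a stated time of 30 min; a lower number here means a stronger inhibitor, a higher number a weaker inhibitor. Compound 2 `COc1cc2nc(C)cc(NCC3CCN(c4ncc(C(=O)NO)cn4)CC3)c2cc1OC` gives 253 nM in this assay, and compound 3 `COc1cc2nc(C3CCCCC3)cc(NCC3CCN(c4ncc(C(=O)NO)cn4)CC3)c2cc1OC` gives 111 nM in this assay. Compound 3 thus has the lowest of the three numbers, but its gap to compound 1 lies within the scatter; only compound 2 is clearly weaker. Among the measured compounds shown here, the one step that bears on the change of interest is the one in which a cyclohexyl replaced a methyl: a 2.3-fold lower number from compound 2 to compound 3 (0.36 log units; beyond the scatter).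

Compound 4 `COc1cc2nc(-c3ccccc3)cc(NCC3CCN(c4ncc(C(=O)NO)cn4)CC3)c2cc1OC` differs from compound 3 in a single place: phenyl in place of cyclohexyl on an aromatic carbon. The data hold no direct comparison of a phenyl with a cyclohexyl, so the expectation rests on the shared core and on the similar size of the two groups. The expected step from compound 3 to compound 4 is a 1.0-fold lower number from compound 3 to compound 4 (0.00 log units; within the scatter), that is, no change beyond the scatter. Compound 4 is therefore estimated at 110 nM, with a range from 50 nM to 250 nM.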

Compound 4, half-maximal inhibitory concentration: 230 nM
Beside the measured number, compound 4's estimate is 2.1-fold (0.32 log units) below it; low and high end bracket the measured number.
By their numbers in this assay, from the lowest: compounds 3, 1, 4 and 2 (each within the scatter of the next, the first and the last beyond it).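

Swapping the cyclohexyl for a phenyl keeps the count of six carbons but makes the ring aromatic, and this alone gives a 2.1-fold higher number from compound 3 to compound 4 (0.32 log units; beyond the scatter), so at this position, next to the ring nitrogen, the number of atoms in the group does not settle the result. Among the compounds shown here, the phenyl also cannot be told apart from the much smaller methyl, with a 1.1-fold lower number from compound 2 to compound 4 (0.04 log units; within the scatter), which leaves cyclohexyl as the only one of the three groups whose number stands apart from both others. No measurement here explains why the two six-membered rings differ.

On these data alone, it remains open whether the lower number belongs to non-aromatic rings in general or to cyclohexyl alone. A cyclopropyl, a piperidine or an open chain such as isobutyl at this position could help to separate the two.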